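This account rests on a few compounds, and the source may have more. Where it says the series, first, only, none or still open, it means among the compounds named here.

Working notes on the series built on the shared core of compound 1 `CCc1ccc(-c2nc3c(c(C)nn3-c3ccccc3)c(-c3ccccc3C#N)c2C#N)cc1`. In a physicochemical assay for solubility, read by spectrophotometry, in phosphate buffer, with a stated time of 18 h, at pH 7.4 (on this read-out lower numbers stand for lower solubility and higher numbers for higher solubility), compound 1 gives 2400 nM, compound 2 `CCc1ccc(-c2nc3c(c(C)nn3-c3ccccc3)c(-c3ccccc3I)c2C#N)cc1` gives 8500 nM, and compound 3 `CCc1ccc(-c2nc3c(c(C)nn3-c3ccccc3)c(-c3ccccc3Cl)c2C#N)cc1` gives 1700 nM. Compound 2 holds the highest of these three numbers, and the other two lie beyond the scatter from it.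

Compound 4 `CCc1ccc(-c2nc3c(c(C)nn3-c3ccccc3)c(-c3ccccc3S(C)(=O)=O)c2C#N)cc1` is still unmeasured. The change from compound 2 is methylsulfonyl in place of iodo on an aromatic carbon, ortho to a large group.

Among the compounds with values here, no measured step brings in methylsulfonyl, so the evidence is indirect. Within the data shown here, the one measured step in which iodo leaves, a 5.0-fold lower number from compound 2 to compound 3 (0.70 log units; beyond the scatter), is modest. The step in which iodo enters, a 3.5-fold higher number from compound 1 to compound 2 (0.55 log units; beyond the scatter), is also modest. By contrast, a 1.4-fold lower number from compound 1 to compound 3 (0.15 log units; within the scatter) stays within the scatter. Among the measured compounds shown here, both other groups tested at this place therefore give lower numbers than iodo, though that rests on only two comparisons.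

On these data alone, a lower number is expected in this assay, but a smaller drop than the modest steps above, since the entering group is untested. The expected change is a 1.7-fold lower number from compound 2 to compound 4 (0.23 log units; within the scatter), which would not clearly exceed the scatter. For compound 4 the estimate is 5000 nM, with an expected range of 1500 nM to 17000 nM.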

Compound 4, solubility: 2200 nM
Compound 4: the middle estimate sits 2.3-fold (0.36 log units) above what was measured; the measured number falls inside the stated range.
By their numbers in this assay, from the lowest: compounds 3, 4 and 1 (each within the scatter of the next); then compound 2.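

With methylsulfonyl, a third group has now been compared with iodo on this aromatic carbon, ortho to a large group, and in this assay it also gives a lower number: a 3.9-fold lower number from compound 2 to compound 4 (0.59 log units; beyond the scatter). Methylsulfonyl cannot be separated from the other two groups, with a 1.3-fold higher number from compound 3 to compound 4 (0.11 log units; within the scatter) and a 1.1-fold lower number from compound 1 to compound 4 (0.04 log units; within the scatter), so among these four compounds cyano, chloro and methylsulfonyl form one level and only iodo stands clear of it. The larger group entering here thus does not reproduce the higher number seen with iodo, and nothing measured on these compounds explains why iodo stands apart.

On these data alone, it remains open whether the higher number belongs to iodo alone or would also appear with another group at this place, such as bromo, methyl, methoxy, an amine or a carboxylic acid. As far as these compounds go, all four compounds differ only at this one place, so it is also open whether the same gap between iodo and the other three groups would hold if another part of the shared core were changed.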